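Benzyl to allyl on the chlorinated core of compound 1

The source may report more compounds than this note shows. Statements on the series, on what has been measured and on what is new or still open speak of the compounds shown alone.

Three compounds of the series carry numbers in an in vitro functional assay on 1321-N1 cells for agonist activity at Free fatty acid receptor 1 (Homo sapiens), read by fluorescence, spectrophotometry and calcium flux; a lower number here means that less compound is needed, a higher number that more compound is needed for the effect. Compound 1, `O=C(O)CCc1ccc(C#Cc2ccnc(Cl)c2Cc2ccccc2)cc1`, gives 794 nM. Compound 3, `Cc1cnc(F)c(C#Cc2ccc(CCC(=O)O)cc2)c1`, gives 661 nM, a number that lies within the scatter of that of compound 1. Compound 2, `COc1nccc(C#Cc2ccc(CCC(=O)O)cc2)n1`, gives 9550 nM, the highest number of the three and beyond the scatter from compound 1. Compound 1 therefore stands second highest among the three measured numbers, close to compound 3 and well apart from compound 2.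

Compound 4, `C=CCc1c(C#Cc2ccc(CCC(=O)O)cc2)ccnc1Cl`, has not yet been measured. It differs from compound 1 in one place: vinyl in place of phenyl on a saturated chain carbon bound to an aromatic carbon. Cut one bond further out, the same difference reads benzyl to allyl. Among the measured compounds shown here, no pair of measured compounds differs in this way, so nothing measured speaks to the size of this change. The step is expected to be a moderate rise in the number, a 2.0-fold higher number from compound 1 to compound 4 (0.30 log units; within the scatter), beyond the scatter but not large. For compound 4 the expected value is 1600 nM, with a range from 500 nM to 5000 nM.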

Compound 4, half-maximal effective concentration: 316 nM
Estimate against measurement, compound 4: 5.1-fold (0.70 log units) above, and the stated range ends above it.
By their numbers in this assay, from the lowest: compound 4; then compounds 3 and 1 (each within the scatter of the next); then compound 2.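

In this assay, among the compounds shown here, replacing phenyl with vinyl on the saturated chain carbon bound to an aromatic carbon gives a 2.5-fold lower number from compound 1 to compound 4 (0.40 log units; beyond the scatter) and is the first step that can be read at this position. The aromatic ring of the benzyl group is therefore not required on the chlorinated core of compound 1 for a number of this order, and a non-aromatic group with a double bond outside any aromatic ring serves there at least as well. The data offer no explanation for this step.

Going by these compounds, with this single step, it remains open whether the double bond of the allyl group contributes, which a saturated propyl chain in its place would test. On these data alone, how far the position accepts other groups, such as a simple methyl, a cyclopropylmethyl or a longer chain ending in an ether, also remains open.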